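Chloro and Ethoxy Together on the Outer Ring

The source may report more compounds than this note shows. Statements on the series, on what has been measured and on what is new or still open speak of the compounds shown alone.

Compound 1 `Cc1ccccc1-c1cccc(COc2ccc(S(=O)(=O)CC(=O)O)cc2)c1` gives 46.8 nM in a functional assay on CHO cells for agonist activity at Free fatty acid receptor 1 (Homo sapiens), read by FLIPR and calcium flux; a higher number here means that more compound is needed for the effect, a lower number that less compound is needed.
Compound 2 `O=C(O)CS(=O)(=O)c1ccc(OCc2cccc(-c3ccccc3Cl)c2)cc1` gives 28.8 nM in this assay.
Compound 3 `COc1ccccc1-c1cccc(COc2ccc(S(=O)(=O)CC(=O)O)cc2)c1` gives 195 nM in this assay.

Compound 3 stands highest of the three: a 4.2-fold higher number from compound 1 to compound 3 (0.62 log units; beyond the scatter) and a 6.8-fold higher number from compound 2 to compound 3 (0.83 log units; beyond the scatter), while a 1.6-fold lower number from compound 1 to compound 2 (0.21 log units; within the scatter). Compound 4 `CCOc1ccc(-c2cccc(COc3ccc(S(=O)(=O)CC(=O)O)cc3)c2)c(Cl)c1` differs from compound 3 by 2-chloro-4-ethoxyphenyl in place of 2-methoxyphenyl on an aromatic carbon. Going by the values given here, the step from compound 2 to compound 3 bears most on it, since compound 4 restores the chloro, and the step from compound 1 to compound 3 points the same way; no measured compound carries the ethoxy, so its contribution is unknown. A downward step of about that size is therefore expected: a 4.9-fold lower number from compound 3 to compound 4 (0.69 log units; beyond the scatter). Compound 4 is estimated at 40 nM, within 12 nM to 130 nM.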

Compound 4, half-maximal effective concentration: 51.3 nM
Estimate against measurement, compound 4: 1.3-fold (0.11 log units) below; measured number inside the range.
By their numbers in this assay, from the lowest: compounds 2, 1 and 4 (each within the scatter of the next); then compound 3.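

The 2-chloro-4-ethoxyphenyl group brings back most of what the 2-methoxyphenyl group gave up (a 3.8-fold lower number from compound 3 to compound 4 (0.58 log units; beyond the scatter)). Going by these compounds alone, the ethoxy, carried by no earlier compound, leaves the number within the scatter of the plain chloro compound (a 1.8-fold higher number from compound 2 to compound 4 (0.25 log units; within the scatter)) and of the methyl compound (a 1.1-fold higher number from compound 1 to compound 4 (0.04 log units; within the scatter)), so this position accepts it on the chloro ring. Nothing measured here explains these steps. As far as these compounds go, whether a longer chain such as propoxy, or an amine, would serve in place of the ethoxy stays open. So does the effect of ethoxy alongside methyl or methoxy.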